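Bromo in place of methyl: from compound 2 to compound 3

The source may report more compounds than this note shows. Statements on the series, on what has been measured and on what is new or still open speak of the compounds shown alone.

Of the compounds shown here, two carry numbers so far. Compound 1 `CCSCCC12CCC(c3nnc(-c4ccccc4C(F)(F)F)n3C)(CC1)CC2` and compound 2 `CCS(=O)(=O)CCC12CCC(c3nnc(-c4ccccc4C)n3C)(CC1)CC2` share the same core and differ in the ethyl thioether against ethyl sulfone on the chain and in the group on the six-membered aromatic ring of carbon only. Among the measured compounds shown here, in a functional assay on the whole organism (strain ICR) for inhibition, with Mus musculus as the target, with a stated time of 4 h, at a dose of 10 mg/kg by the oral route (a higher number here means more inhibition at the dose given (going by the name of the read-out), a lower number less inhibition), compound 2 gives 86% and compound 1 gives 79%; the two numbers lie within the usual scatter of each other, so neither stands apart, and no single-point step between measured compounds can be drawn from them.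

Compound 3 `CCS(=O)(=O)CCC12CCC(c3nnc(-c4ccccc4Br)n3C)(CC1)CC2` keeps the ethyl sulfone chain and the core of compound 2 and changes only the aromatic substituent: bromo in place of methyl on an aromatic carbon. Read one bond further out, the change is 2-methylphenyl to 2-bromophenyl, at the position ortho to the large group.

With nothing in the series speaking for a shift in either direction, the step from compound 2 to compound 3 is expected to stay within the scatter, a number 4 percentage points lower from compound 2 to compound 3 (within the scatter). For compound 3 in this assay the estimate is 82%, with a range from 65% to 95%.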

Compound 3, a percentage reported as inhibition, in the whole organism at one dose (the size of the read-out at that dose, not a potency): 86%
The estimate for compound 3 lay 4 percentage points below the measured number, within the range that was stated.
By their numbers in this assay, from the lowest: compounds 1, 2 and 3 (each within the scatter of the next).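

Bromo in place of methyl on an aromatic carbon, ortho to a large group, gives the first comparison in the series that differs in one place only: in this assay it reads no change at the digits printed from compound 2 to compound 3 (within the scatter). With the ethyl sulfone chain and the shared core held fixed, this read-out therefore does not separate the two groups at this position. Since the read-out gives the size of the inhibition at a single dose and not a potency, the pair says nothing about any difference in potency, and no measurement at hand bears on why the two groups read alike.

Still open, on these data alone, is whether a group of another kind at this position, such as an amine, a carboxylic acid or a methoxy group, would give a step beyond the scatter. Compound 1 differs from compound 2 and from compound 3 in two places, so the steps to it cannot be read, and the ethyl thioether against the ethyl sulfone remains unresolved until trifluoromethyl is paired with the ethyl sulfone chain or methyl or bromo with the ethyl thioether chain.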